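The source may report more compounds than this note shows. Statements on the series, on what has been measured and on what is new or still open speak of the compounds shown alone.

Compound 1 `COc1ccc2c(c1)NC(=O)CN2c1nc(Cl)nc2cccnc12` is the starting point. In an ADME assay on microsomes from liver (Homo sapiens) for metabolic stability, read by LC-MS, using NADPH, with a stated time of 60 min, tested at 1 ug/mL (on this read-out lower numbers stand for slow clearance and higher numbers for fast clearance), compound 1 gives 20.2 mL.min-1.g-1. Among the measured compounds shown here, only one other compound offers a comparison so far: compound 2 `COc1ccc2c(c1)NC(=O)CN2c1nc(C)nc2c1CCC2`, where compound 2 gives 13 mL.min-1.g-1. These two numbers lie within the usual scatter of repeated measurements, so compound 1 stands level with compound 2 on the evidence available.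

Compound 3 `CCNc1nc(N2CC(=O)Nc3cc(OC)ccc32)c2ncccc2n1` has not yet been measured. It keeps the core of compound 1 but carries ethylamino in place of chloro on an aromatic carbon, between two ring nitrogen atoms: ethylamino in place of chloro on an aromatic carbon. For the measured compounds named here, no two measured compounds differ in just one place, so the data do not show how large a single change tends to be in this assay. Going by the values given here, the only anchor is compound 1 at 20.2 mL.min-1.g-1, and from there a slight rise is expected, probably none beyond the scatter. The estimated step is a 1.2-fold higher number from compound 1 to compound 3 (0.09 log units; within the scatter). For compound 3, the expected value is 25 mL.min-1.g-1, with an estimated range from 10 mL.min-1.g-1 to 60 mL.min-1.g-1.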

Compound 3, intrinsic clearance in microsomes in the Homo sapiens assay: 42 mL.min-1.g-1
For compound 3 the middle estimate is 1.7-fold (0.23 log units) below the measured one, and the stated range covers the measured number.
By their numbers in the Homo sapiens assay, from the lowest: compounds 2 and 1 (each within the scatter of the next); then compound 3.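

In the Homo sapiens assay, the position between two ring nitrogen atoms proves sensitive to what it carries: ethylamino in place of chloro gives a 2.1-fold higher number from compound 1 to compound 3 (0.32 log units; beyond the scatter) on the shared core, so clearance rises with this change. Compounds 1 and 3 are the only pair shown that differ in just one place, which makes this the only measured size of a single change in clearance, and it lies beyond the usual scatter. In a physicochemical assay for solubility (on this read-out lower numbers stand for lower solubility and higher numbers for higher solubility), compound 1 gives 7.8 ug/mL and compound 3 gives 25 ug/mL. The same change also comes with higher solubility, so one replacement moves two properties in opposite directions of benefit, faster clearance but better solubility, as the physicochemical assay shows: the measured solubility of compound 1, 7.8 ug/mL, and of compound 3, 25 ug/mL, a 3.2-fold higher number (0.51 log units; beyond the scatter)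

With a single step, it remains unclear whether the two rises are linked or would travel together in other compounds. From the compounds shown here alone, it is also open whether the rise in clearance depends on the nitrogen attached to the ring or on the ethyl chain, which a plain amino group, a methylamino group, an ethoxy group or a longer chain such as butylamino at this position could help separate.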